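The source may hold more compounds than are shown below. What is called first, only, known or untested is meant among the compounds shown, and "the series" means these compounds.

The series rests on a shared core carrying an amide whose nitrogen substituent is varied. Compound 1 `CCN(CC)C(=O)[C@@H]1CN[C@H](C(=O)N2CCC[C@H]2C#N)C1` bears a diethylamino group there, and in an assay on the whole organism (plasma, strain Sprague-Dawley) for inhibition of Dipeptidyl peptidase 4 (Rattus norvegicus), with a stated time of 6 h, at a dose of 1 mg/kg by the oral route (a higher number here means more inhibition at the dose given (going by the name of the read-out), a lower number less inhibition), compound 1 gives 43%. Compound 2 `N#C[C@@H]1CCCN1C(=O)[C@@H]1C[C@H](C(=O)N2CCCCC2)CN1` carries a piperidin-1-yl group in its place; in this assay compound 2 gives 84%, the higher of the two numbers recorded so far, and the step of a number 41 percentage points higher from compound 1 to compound 2 (beyond the scatter) lies well beyond the scatter. Compound 3 `CCNC(=O)[C@@H]1CN[C@H](C(=O)N2CCC[C@H]2C#N)C1` has not yet been measured. It differs from compound 2 by ethylamino in place of piperidin-1-yl on a carbonyl carbon. Within the data shown here, the only measured step that bears on this change is the one from the open diethylamino group to the piperidin-1-yl ring, and it was large, a number 41 percentage points higher from compound 1 to compound 2 (beyond the scatter). Compound 3 moves the other way, from the ring to a group with no ring and one hydrogen-bond donor, so a drop in this assay beyond the scatter is expected, of a size comparable to that step or somewhat larger. Compound 3 is therefore expected to give about 35%, with a range from 10% to 65%. This expectation amounts to a number 49 percentage points lower from compound 2 to compound 3 (beyond the scatter).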

Compound 3, a percentage reported as inhibition, in the whole organism at one dose (the size of the read-out at that dose, not a potency): 60%
Compound 3: middle estimate off by 25 percentage points, on the low side; the measured number falls inside the stated range.
By their numbers in this assay, from the lowest: compound 1; then compound 3; then compound 2.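

In this assay the step of a number 24 percentage points lower from compound 2 to compound 3 (beyond the scatter) shows that giving up the piperidin-1-yl ring on this carbonyl carbon lowers the number, yet a group with no ring need not fall to the level of the diethylamino group in compound 1. The step of a number 17 percentage points higher from compound 1 to compound 3 (beyond the scatter) adds what the earlier pair could not show: the open groups differ among themselves, with hydrogen in place of ethyl on the amide-type nitrogen raising the number, so that ethylamino, with its one hydrogen-bond donor, falls between diethylamino and the piperidin-1-yl ring. No measurement at hand accounts for either step, so this order of the three compounds stands as an observation only.

The three compounds leave open whether the ring itself or the number of substituents on the amide nitrogen sets the order, which a pyrrolidin-1-yl or a morpholin-4-yl group, or a plain unsubstituted amide, could begin to separate. They also leave open whether the same order would hold at another dose or time, since each number comes from a single dose at a single time.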